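Swapping a pyridine for phenyl on the isatin core

The compounds below may be only part of what the source reports. "The series", "measured", "known", "first", "only" and "open" are said of these compounds alone.

Measured so far:
Compound 1 `O=C1C(=O)N(Cc2ccc(-c3cccnc3)cc2)c2ccc(OC(F)(F)F)cc21` gives 1600 nM
Compound 2 `O=C1C(=O)N(Cc2ccc(-c3cccnc3)cn2)c2ccc(OC(F)(F)F)cc21` gives > 30000 nM
Compound 3 `O=C1C(=O)N(Cc2ccc(-c3cccnc3)nc2)c2ccc(OC(F)(F)F)cc21` gives 4000 nM

All three were tested in a functional assay on CHO cells for positive allosteric modulation of muscarinic acetylcholine receptor M5 (Homo sapiens), read by FLIPR and calcium flux, with a stated time of 1 h; a lower number here means that less compound is needed, a higher number that more compound is needed for the effect. Compound 1 has the lowest number among the two compounds with a numerical result. Compound 3 gives 4000 nM, a gap from compound 1 beyond the scatter. For compound 2 the result is a limit, (the limit of > 30000 nM in this assay, at which 1 of the 3 values shown sits), not a number. Compound 4 `O=C1C(=O)N(Cc2ccc(-c3ccccc3)cc2)c2ccc(OC(F)(F)F)cc21` has not been measured; it differs from compound 1 by phenyl in place of pyridin-3-yl on an aromatic carbon, removing the hydrogen-bond acceptor of the pyridin-3-yl group. For the measured compounds named here, no measured pair shows this change, so the estimate rests on compound 1 alone. Compound 4 is expected near 2500 nM, within 800 nM to 8000 nM, a modest step of a 1.6-fold higher number from compound 1 to compound 4 (0.19 log units; within the scatter) in the direction of a higher number.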

Compound 4, half-maximal effective concentration: 1600 nM
Compound 4: the middle estimate sits 1.6-fold (0.19 log units) above what was measured; the measured number falls inside the stated range.
By their numbers in this assay, from the lowest: compounds 1 and 4 (each within the scatter of the next); then compound 3. At a limit, above all of these: compound 2.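

Putting phenyl in place of pyridin-3-yl gives no change at the digits printed from compound 1 to compound 4 (within the scatter), so the hydrogen-bond acceptor of the pyridin-3-yl group is not required for activity in this pair. At this place, a six-membered aromatic ring of carbon only serves as well as one with a hetero atom. Nothing measured here explains this result.

The compounds shown leave open whether this place accepts anything other than a six-membered aromatic ring, such as morpholine. They also leave open what an amine or a carboxylic acid on the phenyl ring would do.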